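Lengthening the Carbamate Chain of a Selenocyanate

The source may hold more compounds than are shown below. What is called first, only, known or untested is meant among the compounds shown, and "the series" means these compounds.

Compound 1 `CCCOC(=O)Nc1ccc([Se]C#N)cc1` gives 8000 nM in a functional assay on MCF7 cells (Homo sapiens) for cytotoxicity, read by MTT assay, with a stated time of 72 h (a higher number here means a weaker inhibitor of growth, a lower number a stronger inhibitor of growth), the higher of the two numbers at hand; compound 2 `O=C(Nc1ccc([Se][Se]c2ccc(NC(=O)OCc3ccccc3)cc2)cc1)OCc1ccccc1` gives 5200 nM in this assay, and the gap between the two lies within the scatter. Compound 3 `CCCCOC(=O)Nc1ccc([Se]C#N)cc1` differs from compound 1 by methyl in place of hydrogen on a saturated chain carbon, three bonds along the chain from an oxygen next to a carbonyl group, in words methyl in place of hydrogen on a saturated chain carbon, three bonds along the chain from an oxygen next to a carbonyl group. Going by the values given here, no measured pair shows this change, so a step no larger than the scatter is expected, leaning slightly toward a lower number, as a 1.2-fold lower number from compound 1 to compound 3 (0.09 log units; within the scatter) expresses. Compound 3 is expected to give 6500 nM, within 3000 nM to 15000 nM.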

Compound 3, concentration for 50% growth inhibition: 6600 nM
Estimate against measurement, compound 3: 1.0-fold (0.01 log units) below, and the stated range covers the measured number.
By their numbers in this assay, from the lowest: compounds 2, 3 and 1 (each within the scatter of the next).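

Going by these compounds alone, the step of a 1.2-fold lower number from compound 1 to compound 3 (0.08 log units; within the scatter) in this assay is the first measured single change in this set, and it reads as propyl to butyl. At this position, then, the added methyl leaves the number within the scatter. Nothing measured here bears on the reason for this result.

On these data alone, whether a longer chain such as hexyl would move the number beyond the scatter remains open. So does the outcome of an amine or a carboxylic acid at this position.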